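Working notes: from compound 2 to compound 3

The source may report more compounds than this note shows. Statements on the series, on what has been measured and on what is new or still open speak of the compounds shown alone.

Measured compounds:
- compound 1 `Cc1cccc(-c2cc(-c3ccoc3)cc(-c3ccc(Cl)s3)n2)c1`: 3990 nM
- compound 2 `Clc1ccc(-c2cc(-c3ccoc3)cc(-c3ccccc3Cl)n2)s1`: 7360 nM

In a functional assay on MCF7 cells (Homo sapiens) for cytotoxicity, read by ELISA, with a stated time of 4 days (on this read-out lower numbers stand for stronger inhibition and higher numbers for weaker inhibition), compound 2 gives 7360 nM, and this number cannot be told apart from that of compound 1, 3990 nM. These two compounds are the only measured points so far, which leaves little to build on.

Compound 3 `Clc1ccc(-c2cc(-c3ccoc3)cc(-c3cccnc3)n2)s1` differs from compound 2 in one place: pyridin-3-yl in place of 2-chlorophenyl on an aromatic carbon. Pyridin-3-yl stands in place of 2-chlorophenyl, next to the ring nitrogen of the shared core.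

For the measured compounds named here, the only measured step at this place is a 1.8-fold higher number from compound 1 to compound 2 (0.27 log units; within the scatter). It exchanges two groups that both lack a ring hetero atom, so it covers the present change only loosely. Going by the values given here, no measured compound carries a ring hetero atom at this place. No step beyond the scatter is therefore expected in this assay, and no direction can be argued from the data. The expected change is a 1.3-fold lower number from compound 2 to compound 3 (0.13 log units; within the scatter), and this estimate is held with wide margins. For compound 3 the estimated value is 5500 nM, with an expected range from 1800 nM to 16000 nM.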

Compound 3, half-maximal inhibitory concentration: 3480 nM
Estimate against measurement, compound 3: 1.6-fold (0.20 log units) above; measured number inside the range.
By their numbers in this assay, from the lowest: compounds 3, 1 and 2 (each within the scatter of the next, the first and the last beyond it).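

In this assay, for the compounds shown here, pyridin-3-yl is the first group at this place with a ring hetero atom, and exchanging it for 2-chlorophenyl gives a 2.1-fold lower number from compound 2 to compound 3 (0.33 log units; beyond the scatter), a modest step and the first to lie beyond the scatter. Exchanging it for 3-methylphenyl gives a 1.1-fold lower number from compound 1 to compound 3 (0.06 log units; within the scatter), so the pyridin-3-yl and 3-methylphenyl compounds cannot be told apart, and a ring nitrogen in this group does not separate compound 3 from compound 1 in this assay. With the modest step set against one within the scatter, the place next to the ring nitrogen of the shared core so far shows only a narrow spread of numbers, and nothing available accounts for the step from 2-chlorophenyl to pyridin-3-yl.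

The compounds shown leave open whether pyridin-2-yl or pyridin-4-yl would give numbers like that of pyridin-3-yl, and whether an amine or a carboxylic acid on this ring would move the number further than any step seen so far. On these data alone, the 5-chlorothiophen-2-yl and furan-3-yl groups are common to all three compounds, so the contribution of those two places to the numbers remains unknown.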